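Replacing the chlorophenyl group of compound 1 with piperidin-3-yl

The source may hold more compounds than are shown below. What is called first, only, known or untested is meant among the compounds shown, and "the series" means these compounds.

Measured compounds:
compound 1 `Cn1cc(-c2cnc3[nH]cc(-c4ccc(Cl)cc4)c3c2)cn1`: 800 nM
compound 2 `Cn1cc(-c2cnc3[nH]cc(-c4ccc(C(N)=O)cc4)c3c2)cn1`: 3000 nM
compound 3 `Cn1cc(-c2cnc3[nH]cc(-c4ccc(C(=O)O)cc4)c3c2)cn1`: 850000 nM

In a physicochemical assay for solubility, read by LC-MS, in phosphate buffer, measured as thermodynamic solubility, with a stated time of 24 h, at pH 7.4 (on this read-out lower numbers stand for lower solubility and higher numbers for higher solubility), compound 1 gives 800 nM, the lowest of the three numbers. The nearest is compound 2 a 3.8-fold higher number from compound 1 to compound 2 (0.57 log units; beyond the scatter), and the furthest is compound 3 a 1100-fold higher number from compound 1 to compound 3 (3.03 log units; beyond the scatter). Between compound 2 and compound 3 the step is a 280-fold higher number from compound 2 to compound 3 (2.45 log units; beyond the scatter).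

Compound 4 `Cn1cc(-c2cnc3[nH]cc(C4CCCNC4)c3c2)cn1` has not yet been measured. It differs from compound 1 in one place (piperidin-3-yl in place of 4-chlorophenyl on an aromatic carbon). The group that leaves has no hydrogen-bond donor or acceptor; the group that enters brings one of each, as counted above.

The two measured steps from compound 1 both swap the chloro for a group carrying hydrogen-bond donors or acceptors, and both raise the number, modestly for compound 2 and largely for compound 3. The change to compound 4 is of a different kind, since a whole aromatic ring leaves and a non-aromatic ring with a nitrogen enters, so neither step is a direct match. Still, compound 4 is expected to move in the same direction and beyond the scatter, estimated at a 130-fold higher number from compound 1 to compound 4 (2.10 log units; beyond the scatter). The estimate for compound 4 is 100000 nM, with a range from 15000 nM to 600000 nM.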

Compound 4, solubility: 1000000 nM
Beside the measured number, compound 4's estimate is 10-fold (1.00 log units) below it; measured number outside the range, above it.
By their numbers in this assay, from the lowest: compound 1; then compound 2; then compounds 3 and 4 (each within the scatter of the next).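

In this assay the step from the chlorinated compound to the piperidine is a 1300-fold higher number from compound 1 to compound 4 (3.10 log units; beyond the scatter) and it shows that this position tolerates more than a change of substituent on the phenyl ring: the whole aromatic ring can leave, with a non-aromatic ring taking its place on the same carbon, and the number still climbs steeply. Compound 3 gives 850000 nM and compound 4 gives 1000000 nM in this assay and these two lie within the usual scatter of each other, so a carboxy group is not the only route to a number this high in the compounds shown. No measurement in hand explains the size of this rise.

Compound 4 removes the aromatic ring and brings in the ring nitrogen in a single change, so the compounds shown cannot separate what each of the two contributes. A cyclohexyl group, which keeps the six-membered non-aromatic ring without the nitrogen, and a phenyl ring carrying an amine would pull those two contributions apart.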